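Series notes: amino for methyl on the shared core

The source may report more compounds than this note shows. Statements on the series, on what has been measured and on what is new or still open speak of the compounds shown alone.

The shared core carries a five-membered heteroaryl substituent and a sugar on a fused two-ring system. Compound 1, with structure `Nc1nc(N)c2c(-c3ccsc3)cn([C@@H]3O[C@H](CO)[C@@H](O)[C@H]3O)c2n1`, is tested in a functional assay on A549 cells (Homo sapiens), read by MTT assay, with a stated time of 72 h; on this read-out higher numbers stand for weaker inhibition and lower numbers for stronger inhibition. For compound 1 the assay gives only a limit of > 100000 nM, not a number (the limit of > 100000 nM in this assay, at which 1 of the 3 values shown sits). Compound 2, with structure `COc1nc(N)nc2c1c(-c1ccoc1)cn2[C@@H]1O[C@H](CO)[C@@H](O)[C@H]1O`, is also tested there. For compound 2 the read-out is a limit of > 20000 nM, with no number behind it. Compound 3, with structure `Cc1nc(N)c2c(-c3ccoc3)cn([C@@H]3O[C@H](CO)[C@@H](O)[C@H]3O)c2n1`, stands in the same position. For compound 3 the assay reports a limit of > 20000 nM rather than a value (the limit of > 20000 nM in this assay, at which 2 of the 3 values shown sit). For the measured compounds named here, no step between two measured compounds can be counted; each of the three sits at a limit. Compound 4, with structure `Nc1nc(N)c2c(-c3ccoc3)cn([C@@H]3O[C@H](CO)[C@@H](O)[C@H]3O)c2n1`, is not yet measured. It differs from compound 3 by amino in place of methyl on an aromatic carbon. Compound 1 is the closest analog of compound 4, and in this assay compound 1 shows only a limit of > 100000 nM. On that basis no step beyond the scatter is expected, and the estimated change is a step that the limit leaves unreadable from compound 3 to compound 4. Compound 4 is expected to give about 80000 nM, in a range from 20000 nM to 300000 nM, most likely again as a limit.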

Compound 4, half-maximal inhibitory concentration: > 20000 nM
Compound 4 was reported as a limit (the forecaster's own chance of this, stated with the estimate: 85%); the middle value is on the limit's open side.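

For the compounds shown here, compound 4 sits at a limit, as do compound 1, compound 2 and compound 3, and no step among them can be read. The compounds shown leave open whether amino, methyl, methoxy, furan-3-yl or thiophen-3-yl on the shared core changes inhibition at all in this assay.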